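This account rests on a few compounds, and the source may have more. Where it says the series, first, only, none or still open, it means among the compounds named here.

Measured in a functional assay on HeLa cells (Homo sapiens) for cytotoxicity, read by MTT assay, with a stated time of 24 h; a higher number here means a weaker inhibitor, a lower number a stronger inhibitor:
Compound 1 `COc1cc(/C=C2\CN(C)C/C(=C\c3ccccc3F)C2=O)cc(OC)c1`: 5450 nM
Compound 2 `CN1C/C(=C\c2ccc(C(C)(C)C)cc2)C(=O)/C(=C/c2ccccc2F)C1`: 15500 nM
Compound 3 `COc1cc(/C=C2\CN(C)C/C(=C\c3ccc(Cl)cc3)C2=O)cc(OC)c1`: 11200 nM

In this assay, compound 3 gives 11200 nM, within the scatter of compound 2 and clear of compound 1. The next structure, compound 4 `COc1cc(/C=C2\CN(C)C/C(=C\c3ccc(Cl)cc3Cl)C2=O)cc(OC)c1`, differs from compound 3 by chloro in place of hydrogen on an aromatic carbon, ortho to a large group and meta to a chloro group, so 4-chlorophenyl becomes 2,4-dichlorophenyl.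

Within the data shown here, no measured step makes this exact change. The nearest is a 2.1-fold higher number from compound 1 to compound 3 (0.31 log units; beyond the scatter), a modest step on the same aromatic ring, with 4-chlorophenyl in place of 2-fluorophenyl. Compound 1 suggests that a group at this place may go with a lower number, but compound 2 carries 2-fluorophenyl too and goes against that reading. Only a small shift is therefore expected, and the direction is uncertain. The expected change is a 1.4-fold lower number from compound 3 to compound 4 (0.15 log units; within the scatter). The estimated value for compound 4 is 8000 nM, with an expected range from 3000 nM to 20000 nM.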

Compound 4, half-maximal inhibitory concentration: 7760 nM
For compound 4 the middle estimate is 1.0-fold (0.01 log units) above the measured one, within the range that was stated.
By their numbers in this assay, from the lowest: compounds 1, 4, 3 and 2 (each within the scatter of the next, the first and the last beyond it).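

In this assay, among these compounds, the step of a 1.4-fold lower number from compound 3 to compound 4 (0.16 log units; within the scatter) is the first direct reading at this place, chloro in place of hydrogen on an aromatic carbon, ortho to a large group, and it leaves the two compounds inseparable. The step of a 1.4-fold higher number from compound 1 to compound 4 (0.15 log units; within the scatter) for 2,4-dichlorophenyl in place of 2-fluorophenyl is also too small to read, so compound 4 cannot be told from either neighbour, even though the step of a 2.1-fold higher number from compound 1 to compound 3 (0.31 log units; beyond the scatter) lies just beyond the scatter. No measurement shown offers a reason for this behaviour at the position.

Going by these compounds, whether an amine or a carboxylic acid at this place would give a step beyond the scatter remains open. Also open, on these data alone, is how 2-chlorophenyl, without the 4-chloro group, would read against compound 3 and compound 4.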